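The compounds below may be only part of what the source reports. "The series", "measured", "known", "first", "only" and "open" are said of these compounds alone.

Series notes. Compound 1 `CCCCC(O)c1cccc(NC(=O)NCCCCl)c1` carries the 3-chloropropyl group on a urea-type nitrogen; in a functional assay on M21 cells (Homo sapiens) for antiproliferative activity, with a stated time of 48 h (on this read-out lower numbers stand for stronger inhibition and higher numbers for weaker inhibition), compound 1 gives 35000 nM. Compound 2 `CCCCC(O)c1cccc(NC(=O)NC(=O)CC)c1` replaces that group by propanoyl. In this assay compound 2 gives only a limit, > 100000 nM. Compound 3 `CCCCC(OC)c1cccc(NC(=O)NC(=O)CC)c1` is the methyl ether of compound 2. In this assay compound 3 likewise gives only a limit, > 100000 nM. The step of an at least 2.8-fold higher number from compound 1 to compound 2 (0.45 log units; beyond the scatter) weakens, whereas a step that the two limits leave unreadable from compound 2 to compound 3 is unreadable because both sit at the limit of > 100000 nM in this assay, at which 2 of the 3 values shown sit. Compound 2 stands at the weak end of the shown numbers. Compound 4 `CCCCC(O)c1cccc(NC(=O)CCCCl)c1` differs from compound 2 by 3-chloropropyl in place of propanoylamino on a carbonyl carbon, so the 3-chloropropyl chain of compound 1 returns, now on the carbonyl carbon. Going by the values given here, only the step from compound 1 to compound 2 bears on this; its size is hidden by the limit. Regaining the chain is expected to lower the number by about an at least 2.0-fold lower number from compound 2 to compound 4 (0.30 log units; that floor lies within the scatter). Compound 4 is estimated at 50000 nM (range 15000 nM to 150000 nM).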

Compound 4, half-maximal inhibitory concentration: > 100000 nM
Compound 4: only a limit was reported; the forecaster's own chance of this, stated with the estimate: 35%; middle value at least 2.0-fold (0.30 log units) away from the limit.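

With the 3-chloropropyl group set directly on the carbonyl carbon, this assay shows an at least 2.8-fold higher number from compound 1 to compound 4 (0.45 log units; beyond the scatter). The chain alone therefore does not keep the reading of compound 1, and the nitrogen that joins it to the carbonyl counts in this change. The step from compound 2 to compound 4 cannot be read because both sit at the same limit: the limit of > 100000 nM in this assay, at which 3 of the 4 values shown sit.

Still open, as far as these compounds go, is whether a longer chain on the urea-type nitrogen, or an amine in place of the chlorine, would give a lower number than compound 1. The full size of the loss in compound 4 also stays hidden.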